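A methoxy variant of a very weak piperazine pair

A few compounds are considered here, and "the series" means these few. Any claim that something is new, unique, unknown or untested is made for them only; others in the source may bear on it.

Compound 2 `S=c1oc(-c2ccc3c(c2)OCCO3)nn1CN1CCN(c2ccccc2)CC1` is one of two measured compounds, and in a functional assay on SW 1116 cells (Homo sapiens) for antiproliferative activity, read by MTT assay, with a stated time of 48 h (a lower number here means a stronger inhibitor, a higher number a weaker inhibitor), compound 2 reaches only a limit, > 50000 nM (the limit of > 50000 nM in this assay, at which 1 of the 2 values shown sits). Its fluoro analogue, compound 1 `Fc1ccccc1N1CCN(Cn2nc(-c3ccc4c(c3)OCCO4)oc2=S)CC1`, gives 37800 nM. Among the compounds with values here, the single measured step, an at least 1.3-fold higher number from compound 1 to compound 2 (0.12 log units; that floor lies within the scatter), was small. Compound 3 `COc1cccc(N2CCN(Cn3nc(-c4ccc5c(c4)OCCO5)oc3=S)CC2)c1` instead carries methoxy in place of hydrogen on an aromatic carbon. Within the data shown here, no measured step involves a methoxy group, so that small fluoro step is the only guide, and it suggests little movement. Compound 3 is therefore expected to remain very weak, with an at least 1.1-fold lower number from compound 2 to compound 3 (0.04 log units; that floor lies within the scatter) expected to stay within the scatter, at an estimated 45000 nM (range 18000 nM to 110000 nM).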

Compound 3, half-maximal inhibitory concentration: > 50000 nM
Compound 3 gave a limit, no number (the forecaster's own chance of this, stated with the estimate: 50%); middle value at least 1.1-fold (0.04 log units) from the limit.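

Adding methoxy to the phenyl of compound 2 did not bring the value within the readable range of this assay: compound 3 gives only a limit, and the step between the two limits cannot be read. Within the data shown here, the one readable step is an at least 1.3-fold higher number from compound 1 to compound 3 (0.12 log units; that floor lies within the scatter). Compound 1 therefore remains the only one of the three with an actual number, and the limit recurs: the limit of > 50000 nM in this assay, at which 2 of the 3 values shown sit.

Going by these compounds, what an amine or a carboxylic acid at this place on the phenyl would do stays open. So does how far beyond the limit compound 2 and compound 3 truly lie.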